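From Methoxy to Methoxycarbonyl: an Expected Antiproliferative Read-out

This account rests on a few compounds, and the source may have more. Where it says the series, first, only, none or still open, it means among the compounds named here.

Compound 1, `Cc1nn(C)c(Oc2ccc(Cl)cc2)c1/C=N/OCc1ccc([N+](=O)[O-])cc1`, gives 18.4% in a functional assay on HepG2 cells (Homo sapiens) for antiproliferative activity, tested at 1 uM; on this read-out higher numbers stand for more inhibition at the one concentration tested (going by the name of the read-out) and lower numbers for less inhibition.
Compound 2, `Cc1nn(C)c(Oc2ccccc2)c1/C=N/OCc1ccc([N+](=O)[O-])cc1`, gives -2.8% in this assay.
Compound 3, `COc1ccc(CO/N=C/c2c(C)nn(C)c2Oc2ccc(Cl)cc2)cc1`, gives 13.9% in this assay.

Among the three measured compounds, compound 3 stands second highest; compound 1 lies nearest to it, within the scatter, while compound 2 lies furthest below it, beyond the scatter. Two single-point steps have been measured. Replacing the chloro by hydrogen gave a number 21.2 percentage points lower from compound 1 to compound 2 (beyond the scatter). Exchanging the nitro for methoxy gave a number 4.5 percentage points lower from compound 1 to compound 3 (within the scatter), so an exchange on an aromatic carbon of a six-membered aromatic ring of carbon only has so far passed without a change beyond the scatter.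

Compound 4, `COC(=O)c1ccc(CO/N=C/c2c(C)nn(C)c2Oc2ccc(Cl)cc2)cc1`, differs from compound 3 in one place: methoxycarbonyl in place of methoxy on an aromatic carbon. Within the data shown here, the step that bears on this change is the one from compound 1 to compound 3, which altered the same aromatic carbon and stayed within the scatter. The step from compound 1 to compound 2 concerns a chloro in place of hydrogen and does not bear on it. Compound 4 is therefore expected to show a step of about a number 1.1 percentage points higher from compound 3 to compound 4 (within the scatter), that is, none beyond the scatter. The estimate for compound 4 in this assay is 15%, with a range from 2% to 28%.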

Compound 4, a percentage reported as inhibition, at one concentration (the size of the read-out at that concentration, not a potency): 20.3%
Estimate against measurement, compound 4: 5.3 percentage points below; the range from low to high includes it.
By their numbers in this assay, from the lowest: compound 2; then compounds 3, 1 and 4 (each within the scatter of the next).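

The methoxycarbonyl group adds a third kind of substituent at this aromatic carbon, para to a large group: in this assay the exchange for methoxy gives a number 6.4 percentage points higher from compound 3 to compound 4 (within the scatter), and the exchange for nitro gives a number 1.9 percentage points higher from compound 1 to compound 4 (within the scatter). Together with a number 4.5 percentage points lower from compound 1 to compound 3 (within the scatter), this places the nitro, methoxy and methoxycarbonyl compounds within the scatter of one another, so the position has now shown no step beyond the scatter across three groups. This also holds for methoxycarbonyl, which has 4 heavy atoms, a double bond outside aromatic rings and 2 hydrogen-bond acceptors, against the 2 heavy atoms and 1 hydrogen-bond acceptor of methoxy.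

The data at hand offer no explanation for why these three groups read alike. As far as these compounds go, it remains open whether a carboxylic acid, an amine or a longer chain at this carbon would also stay within the scatter, and whether hydrogen in place of chloro would cost as much alongside methoxycarbonyl as a number 21.2 percentage points lower from compound 1 to compound 2 (beyond the scatter) seen with nitro.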